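A Chloro for Fluoro Swap on the Shared Core

A few compounds are considered here, and "the series" means these few. Any claim that something is new, unique, unknown or untested is made for them only; others in the source may bear on it.

Measured in a functional assay on KM12 cells (Homo sapiens) for antiproliferative activity; on this read-out lower numbers stand for stronger inhibition of growth and higher numbers for weaker inhibition of growth:
- Compound 1 `COc1ccc(-c2nc3ccccc3s2)cc1OC`: 74200 nM
- Compound 2 `COc1ccc(-c2nc3cc(F)ccc3s2)cc1OC`: 290 nM

Of these two compounds, compound 2 has the lower number at 290 nM. Compound 3 `COc1ccc(-c2nc3cc(Cl)ccc3s2)cc1OC` differs from it by chloro in place of fluoro on an aromatic carbon. Going by the values given here, only one measured step bears on this change: a 260-fold lower number from compound 1 to compound 2 (2.41 log units; beyond the scatter), a large step beyond the scatter, with fluoro in place of hydrogen. It shows that this carbon matters but says nothing directly about chloro. Only a small move towards a higher number is therefore expected in this assay. The expected step is a 1.7-fold higher number from compound 2 to compound 3 (0.24 log units; within the scatter). Compound 3 is estimated at 500 nM, with an expected range from 100 nM to 5000 nM.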

Compound 3, concentration for 50% growth inhibition: 12400 nM
The estimate for compound 3 lay 25-fold (1.39 log units) below the measured number, outside the stated range (above it).
By their numbers in this assay, from the lowest: compound 2; then compound 3; then compound 1.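

In this assay the swap of halogen on this aromatic carbon gives a 43-fold higher number from compound 2 to compound 3 (1.63 log units; beyond the scatter), so the gain at this position depends on which halogen sits there and not merely on a halogen being present. Chloro in place of hydrogen still gives a 6.0-fold lower number from compound 1 to compound 3 (0.78 log units; beyond the scatter), a gain much smaller than the one seen with fluoro. No evidence is available to explain why the two halogens differ. Open, on these data alone, is how bromo, a methyl group or an amine on this same carbon would compare with fluoro and chloro.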